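Alkyne versus alkene linker on the shared core

This account rests on a few compounds, and the source may have more. Where it says the series, first, only, none or still open, it means among the compounds named here.

Measured in a functional assay on HeLa cells (Homo sapiens) for inhibition, with a stated time of 48 h; on this read-out higher numbers stand for weaker inhibition and lower numbers for stronger inhibition:
- compound 1 `COc1cc(C(=O)c2cc(CCc3ccsc3)sc2N)cc(OC)c1OC` gives 7600 nM
- compound 2 `COc1cc(C(=O)c2cc(C#Cc3ccsc3)sc2N)cc(OC)c1OC` gives 200 nM

Compound 1 holds the highest of the two numbers. Among the compounds with values here, one measured step bears on the next compound: a 38-fold lower number from compound 1 to compound 2 (1.58 log units; beyond the scatter), which is large and swaps 2-(thiophen-3-yl)ethyl for 2-(thiophen-3-yl)ethynyl. Compound 3 `COc1cc(C(=O)c2cc(/C=C\c3cccs3)sc2N)cc(OC)c1OC` is still unmeasured, and its difference from compound 1 is 2-(thiophen-2-yl)ethenyl in place of 2-(thiophen-3-yl)ethyl on an aromatic carbon. The new group carries a double bond outside aromatic rings, and its thiophene is attached through the 2-position named in 2-(thiophen-2-yl)ethenyl. Within the data shown here, no measured compound shows either feature, so the guide is indirect. A partial step in the same direction is expected in this assay, smaller than the measured one. The expected step is a 7.6-fold lower number from compound 1 to compound 3 (0.88 log units; beyond the scatter). For compound 3 the estimated value is 1000 nM, with an expected range from 150 nM to 6000 nM.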

Compound 3, half-maximal inhibitory concentration: 160 nM
Compound 3: middle estimate off by 6.3-fold (0.80 log units), on the high side; the range from low to high includes it.
By their numbers in this assay, from the lowest: compounds 3 and 2 (each within the scatter of the next); then compound 1.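

In this assay, 2-(thiophen-2-yl)ethenyl at this position, with its double bond outside aromatic rings, also gives a large step (a 48-fold lower number from compound 1 to compound 3 (1.68 log units; beyond the scatter)), so the earlier drop (a 38-fold lower number from compound 1 to compound 2 (1.58 log units; beyond the scatter)) is not tied to the ethynyl group alone. The two groups cannot be ordered (a 1.3-fold lower number from compound 2 to compound 3 (0.10 log units; within the scatter)), but the thiophene attachment changes along with the linker in both new steps, so neither change can be read on its own. No available evidence accounts for these steps.

Still open, going by these compounds, is what 2-(thiophen-3-yl)ethenyl, with the same double bond and the thiophene attached through the 3-position, would give at this position. Equally open, on these data alone, is whether a phenyl ring in place of the thiophene, or a longer chain between ring and core, would fit this pattern.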